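The compounds below may be only part of what the source reports. "The series", "measured", "known", "first", "only" and "open" are said of these compounds alone.

In an assay on membranes from brain for displacement of a labelled ligand from Sigma non-opioid intracellular receptor 1 (Cavia porcellus), read by scintillation counting, with a stated time of 120 min (a higher number here means a weaker inhibitor, a lower number a stronger inhibitor), compound 2 `COC1Cc2cc(-c3ccc(C(C)=O)cc3)sc2C2(CCN(Cc3ccccc3)CC2)O1` gives 59 nM, the highest of the two numbers recorded so far; its nearest neighbour is compound 1 `COC1Cc2cc(-c3ccccc3)sc2C2(CCN(Cc3ccccc3)CC2)O1`, which in this assay gives 16 nM. Among the measured compounds shown here, the only step among the measured compounds, a 3.7-fold higher number from compound 1 to compound 2 (0.57 log units; beyond the scatter), came with acetyl in place of hydrogen on an aromatic carbon. Compound 3 `COC1Cc2cc(-c3ccc(-c4ccccc4)cc3)sc2C2(CCN(Cc3ccccc3)CC2)O1` is the next member: phenyl in place of acetyl on an aromatic carbon. For the measured compounds named here, this change takes away the acetyl whose arrival weakened binding between compound 1 and compound 2 and puts phenyl in its place; no measured pair shows phenyl entering at that position, so the one step that bears on it is a 3.7-fold higher number from compound 1 to compound 2 (0.57 log units; beyond the scatter), a modest one. The expectation for compound 3 is therefore a modest move back toward compound 1, estimated as a 2.4-fold lower number from compound 2 to compound 3 (0.37 log units; beyond the scatter). For compound 3 the estimate in this assay is 25 nM, within the range 8 nM to 80 nM.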

Compound 3, inhibition constant: 211 nM
Compound 3: the middle estimate sits 8.4-fold (0.93 log units) below what was measured; the measured number lies above the stated range.
By their numbers in this assay, from the lowest: compound 1; then compound 2; then compound 3.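

In this assay, the change from acetyl to phenyl on this aromatic carbon did not bring the number back down but raised it further (a 3.6-fold higher number from compound 2 to compound 3 (0.55 log units; beyond the scatter)), so removing acetyl does not by itself restore binding. Measured against hydrogen at the same place, para to a large group, phenyl gives a large step (a 13-fold higher number from compound 1 to compound 3 (1.12 log units; beyond the scatter)), and among these three compounds the number rises from hydrogen to acetyl to phenyl. No measurement given here explains this order.

The three compounds leave open how an amine, a carboxylic acid or a methoxy group would behave at this position. They also cannot separate the effect of the phenyl ring from that of its greater count of heavy atoms, which a longer chain such as butyl might help to distinguish.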